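Aryl swap on the aminomethyl side chain: thiazole variant

This account rests on a few compounds, and the source may have more. Where it says the series, first, only, none or still open, it means among the compounds named here.

The three measured compounds share one core and differ only in the aryl group on a saturated chain carbon bound to an amine nitrogen: compound 1 `C=C1CC[C@@H]2[C@](C)(CNCc3ccc(OC)cc3)[C@H](O)CC[C@@]2(C)[C@@H]1/C=C/C1=CCOC1=O`, compound 2 `C=C1CC[C@@H]2[C@](C)(CNCc3ccc(C#N)cc3)[C@H](O)CC[C@@]2(C)[C@@H]1/C=C/C1=CCOC1=O` and compound 3 `C=C1CC[C@@H]2[C@](C)(CNCc3ccco3)[C@H](O)CC[C@@]2(C)[C@@H]1/C=C/C1=CCOC1=O`. In a functional assay on BMMC cells (Mus musculus, strain C57BL/6) for inhibition, with stated times of 5 days and 48 h (a higher number here means a weaker inhibitor, a lower number a stronger inhibitor), compound 1 gives 750 nM, compound 2 gives 1130 nM, and compound 3 gives 1830 nM. Compound 3 carries the highest of the three numbers, though only one gap is clear: a 2.4-fold higher number from compound 1 to compound 3 (0.39 log units; beyond the scatter), whereas a 1.6-fold higher number from compound 2 to compound 3 (0.21 log units; within the scatter). The substituent change within the phenyl pair, a 1.5-fold higher number from compound 1 to compound 2 (0.18 log units; within the scatter), is also small.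

Compound 4 `C=C1CC[C@@H]2[C@](C)(CNCc3nccs3)[C@H](O)CC[C@@]2(C)[C@@H]1/C=C/C1=CCOC1=O` makes the next change at the same place: 1,3-thiazol-2-yl in place of furan-2-yl on a saturated chain carbon bound to an amine nitrogen. The two earlier aryl replacements at this carbon bear on it, and both moved this assay by modest amounts only. The expected step is therefore small, a 1.2-fold lower number from compound 3 to compound 4 (0.09 log units; within the scatter), with no clear direction beyond the scatter. Compound 4 is estimated at 1500 nM, with a range of 700 nM to 3200 nM.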

Compound 4, half-maximal inhibitory concentration: 700 nM
Compound 4: the middle estimate sits 2.1-fold (0.33 log units) above what was measured, within the range that was stated.
By their numbers in this assay, from the lowest: compounds 4, 1, 2 and 3 (each within the scatter of the next, the first and the last beyond it).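

In this assay, exchanging one five-membered aromatic ring for another on a saturated chain carbon bound to an amine nitrogen is not neutral, with a 2.6-fold lower number from compound 3 to compound 4 (0.42 log units; beyond the scatter) for 1,3-thiazol-2-yl in place of furan-2-yl. The phenyl comparisons, a 1.6-fold lower number from compound 2 to compound 4 (0.21 log units; within the scatter) and a 1.1-fold lower number from compound 1 to compound 4 (0.03 log units; within the scatter), show that a five-membered ring at this carbon can match the phenyl pair, so the two clear gaps in the series both end at compound 3, while compound 2 stays within the scatter of compound 3. Nothing shown here bears on the origin of the step from furan-2-yl to 1,3-thiazol-2-yl.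

From the compounds shown here alone, whether the ring nitrogen or the ring sulfur of 1,3-thiazol-2-yl goes with this step remains open, and a thiophen-2-yl or 1,3-oxazol-2-yl group would help separate the two. Going by these compounds, the effect of a saturated group such as cyclohexyl at this carbon also remains open.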